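From cyano to trifluoromethyl at the assay limit

This account rests on a few compounds, and the source may have more. Where it says the series, first, only, none or still open, it means among the compounds named here.

In a functional assay on MDA-MB-231 cells (Homo sapiens) for inhibition, read by sulforhodamine B assay, with a stated time of 74 h (on this read-out lower numbers stand for stronger inhibition and higher numbers for weaker inhibition), compound 2 `N#Cc1cccc(S(=O)(=O)N2C(=O)COC23C=CC(=O)C=C3)c1` gives > 10000 nM as a limit, not a number. Compound 1 `O=C1C=CC2(C=C1)OCC(=O)N2S(=O)(=O)c1ccccc1` gives > 10000 nM as a limit too. Compound 3 `O=C1C=CC2(C=C1)OCC(=O)N2S(=O)(=O)c1ccc(N2CCCC2=O)cc1` gives > 10000 nM as a limit too. Compound 4 `O=C1C=CC2(C=C1)OCC(=O)N2S(=O)(=O)c1cccc(C(F)(F)F)c1` differs from compound 2 by trifluoromethyl in place of cyano on an aromatic carbon and carries trifluoromethyl in place of cyano on an aromatic carbon. The steps a step that the two limits leave unreadable from compound 1 to compound 2 and a step that the two limits leave unreadable from compound 1 to compound 3 bear on this change, yet neither has a readable size. With the limit of > 10000 nM in this assay, at which 3 of the 3 values shown sit, in view, no step beyond the scatter is expected in this assay for this change. The expected step is a number no higher from compound 2 to compound 4 (the limit leaves the size open) in size. Compound 4 is estimated at 10000 nM within 4000 nM to 30000 nM and will most likely be reported only as a limit.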

Compound 4, half-maximal inhibitory concentration: > 10000 nM
Compound 4 gave a limit, no number; the forecaster's own chance of this, stated with the estimate: 80%; the middle value sits exactly at the limit.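

Within the data shown here, compound 4 gives > 10000 nM, a limit and not a number, so no step to it from compound 1 or compound 2 can be read in this assay. The compounds shown leave open whether cyano, trifluoromethyl or 2-oxopyrrolidin-1-yl changes inhibition.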